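A few compounds are considered here, and "the series" means these few. Any claim that something is new, unique, unknown or untested is made for them only; others in the source may bear on it.

Compound 1 `CC1(C)C2CCC1(C)C(OC(=O)/C=C/c1ccc(O)c(O)c1[N+](=O)[O-])C2`: 40700 nM
Compound 2 `CC1(C)C2CCC1(C)C(OC(=O)/C=C/c1ccc(O)c(O)c1)C2`: > 300000 nM

Within the data shown here, in a functional assay on MCF7 cells (Homo sapiens) for cytotoxicity, read by MTT assay (on this read-out lower numbers stand for stronger inhibition and higher numbers for weaker inhibition), compound 1 gives 40700 nM, the only true number so far. The value of compound 2, > 300000 nM, is a limit of the assay. Compound 3 `COc1c(O)ccc(/C=C/C(=O)OC2CC3CCC2(C)C3(C)C)c1[N+](=O)[O-]` differs from compound 1 by methyl in place of hydrogen on an oxygen on an aromatic ring, hydroxy to methoxy. Among the measured compounds shown here, the sole measured step, an at least 7.3-fold higher number from compound 1 to compound 2 (0.86 log units; beyond the scatter), swaps nitro for hydrogen on an aromatic carbon, so it does not test this oxygen. For the measured compounds named here, with no measured precedent, no change beyond the scatter is expected in this assay. The expected step is a 1.1-fold higher number from compound 1 to compound 3 (0.04 log units; within the scatter). For compound 3 the estimated value is 45000 nM, with an expected range of 15000 nM to 130000 nM.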

Compound 3, half-maximal inhibitory concentration: 62300 nM
Compound 3: the middle estimate sits 1.4-fold (0.14 log units) below what was measured; the range from low to high includes it.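

On the oxygen on the aromatic ring, hydroxy to methoxy now has a direct reading: in this assay, the step is a 1.5-fold higher number from compound 1 to compound 3 (0.18 log units; within the scatter) and stays within the scatter. Among these compounds, a free hydrogen on this oxygen is therefore not needed to keep a measurable value, unlike the nitro group, whose removal gave the only step beyond the scatter. Nothing at hand bears on why this change is tolerated.

Open, as far as these compounds go, is whether a larger group on this oxygen, such as ethyl or benzyl, is tolerated as well. Also open, from the compounds shown here alone, is whether an amine in place of the nitro group would hold the value of compound 1.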